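Configuration change and cytotoxicity: from compound 2 to compound 4

The source may hold more compounds than are shown below. What is called first, only, known or untested is meant among the compounds shown, and "the series" means these compounds.

compound 1 `Nc1nc2c(ncn2/C=C2\C[C@@H]2[C@H](O)CO)c(=O)[nH]1` — > 300000 nM
compound 2 `Nc1ncnc2c1ncn2/C=C1/C[C@@H]1[C@@H](O)CO` — > 300000 nM
compound 3 `Nc1nc2c(ncn2/C=C2/CC2(CO)CO)c(=O)[nH]1` — > 100000 nM

Three compounds were tested in an ADME assay on HFF cells (Homo sapiens) for cytotoxicity, read by neutral red uptake; on this read-out higher numbers stand for lower toxicity in this test and lower numbers for higher toxicity in this test. In this assay compound 2 gives > 300000 nM, which is a limit of the assay and not a number. Compound 1 gives > 300000 nM, likewise a limit. Compound 3 gives > 100000 nM, again a limit. For the measured compounds named here, two of the three values therefore sit at the limit of > 300000 nM in this assay, at which 2 of the 3 values shown sit, and one at the limit of > 100000 nM in this assay, at which 1 of the 3 values shown sits, so no measured compound shows toxicity within the tested range, and compound 2 stands with the two that reached the higher limit.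

The unmeasured compound 4 `Nc1ncnc2c1ncn2/C=C1\C[C@H]1[C@@H](O)CO` is related to compound 2 as follows: the two compounds have the same atoms and bonds and differ only in configuration as drawn: 2 of 3 stereo elements differ; a stereocentre at a saturated ring carbon is drawn S in compound 2 and R in compound 4; a double bond is drawn Z in compound 2 and E in compound 4. Going by the values given here, no step between measured compounds is given here, so the size of such a configurational change in this assay is not known from these data. Among the compounds with values here, since every compound measured so far returned only a limit, the expectation for a number no higher from compound 2 to compound 4 (the limit leaves the size open) is no step beyond the usual scatter. Compound 4 is accordingly expected to give 300000 nM, with a range from 100000 nM to 600000 nM, most likely reported as a limit rather than a number.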

Compound 4, half-maximal cytotoxic concentration: 264000 nM
Compound 4: the middle estimate sits 1.1-fold (0.06 log units) above what was measured; the range from low to high includes it.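

In this assay compound 4 gives 264000 nM, the first number rather than a limit among the compounds shown, so this configuration of the saturated ring carbon and the double bond gives a value inside the range the test can report. Compound 2 gives > 300000 nM, which is a limit of the assay. The pair therefore yields only a floor, an at least 1.1-fold lower number from compound 2 to compound 4 (0.05 log units; that floor lies within the scatter), and any gap behind that floor belongs to one kind of change alone: the fact that compounds 2 and 4 differ only in the configuration as drawn

As far as these compounds go, the true size of that gap stays open, and so does the question of which element carries it, the stereocentre at the saturated ring carbon or the double bond, since both differ together in this one pair. Also open is how the read-out in this assay would respond if a carboxylic acid or a longer chain took the place of the hydroxyl groups, since every compound shown carries those hydroxyl groups.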